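This account rests on a few compounds, and the source may have more. Where it says the series, first, only, none or still open, it means among the compounds named here.

Measured compounds:
- compound 1 `Cc1ccsc1/C=C(/SCc1ccc(F)cc1)C(=O)c1ccc(Br)cc1`, 50000 nM
- compound 2 `Cc1ccsc1/C=C(/SCc1ccc(Cl)cc1)C(=O)c1ccc(Br)cc1`, 25000 nM
- compound 3 `Cc1ccc(/C=C(\C(=O)c2ccc(Cl)cc2)S(=O)(=O)Cc2ccc(Cl)cc2Cl)s1`, 10000 nM

In a functional assay on DU-145 cells (Homo sapiens) for inhibition, read by trypan blue exclusion, with a stated time of 96 h (on this read-out lower numbers stand for stronger inhibition of growth and higher numbers for weaker inhibition of growth), compound 1 gives 50000 nM, the highest number of the three. Its nearest neighbour is compound 2, where a 2.0-fold lower number from compound 1 to compound 2 (0.30 log units; within the scatter), a step that stays within the scatter. For the measured compounds named here, in several places at once compound 1 differs from compound 3, and compound 3 gives 10000 nM; that gap is beyond the scatter, though no single step can be drawn between them.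

The unmeasured compound 4 `O=C(/C(=C\c1ccc2ccccc2n1)SCc1ccc(F)cc1)c1ccc(Br)cc1` differs from compound 1 in one place: quinolin-2-yl in place of 3-methylthiophen-2-yl on a double-bonded chain carbon bound to a double-bonded chain carbon. Going by the values given here, none of the measured steps bears on this change; the only step measured, the halogen swap from compound 1 to compound 2, touches a different part of the shared core and lies within the scatter. There is therefore no basis for expecting a step of any particular size or direction in this assay for the exchange of a five-membered ring for a fused six-membered system on the double-bonded chain carbon. Compound 4 is expected to land near compound 1, giving an estimated 40000 nM with a range of 10000 nM to 150000 nM, which amounts to an expected 1.3-fold lower number from compound 1 to compound 4 (0.10 log units; within the scatter).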

Compound 4, concentration for 50% growth inhibition: 25000 nM
Compound 4: the middle estimate sits 1.6-fold (0.20 log units) above what was measured, within the range that was stated.
By their numbers in this assay, from the lowest: compound 3; then compounds 2, 4 and 1 (each within the scatter of the next).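

In this assay, for the compounds shown here, the exchange at this place, on a double-bonded chain carbon bound to a double-bonded chain carbon, gives a 2.0-fold lower number from compound 1 to compound 4 (0.30 log units; within the scatter), the first reading of a change here. Quinolin-2-yl, with 10 heavy atoms and two six-membered aromatic rings, therefore stands in for 3-methylthiophen-2-yl, with 6 heavy atoms and one five-membered aromatic ring, without a step beyond the scatter on this read-out. No supporting evidence bears on why the two groups read alike.

Going by these compounds, whether a group of another kind at this place, such as an aminomethyl or a carboxylic acid, would give a step beyond the scatter remains open. Also open, on these data alone, is whether the chloro in place of fluoro exchange would read the same with quinolin-2-yl at this place.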